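Amine substituent variation in the coumarin amide series

The source may report more compounds than this note shows. Statements on the series, on what has been measured and on what is new or still open speak of the compounds shown alone.

Measured compounds:
compound 1, `CC(=O)Oc1ccc(C(=O)Nc2cc3ccc(OCC4CCN(C)C4)c(C)c3oc2=O)cc1CC=C(C)C`, 880 nM in a functional assay on SK-BR-3 cells (Homo sapiens) for antiproliferative activity; a higher number here means a weaker inhibitor, a lower number a stronger inhibitor
compound 2, `CCN(CC)CCCOc1ccc2cc(NC(=O)c3ccc(O)c(CC=C(C)C)c3)c(=O)oc2c1C`, 4900 nM
compound 3, `CC(C)=CCc1cc(C(=O)Nc2cc3ccc(OCCCN(C)C(C)C)c(C)c3oc2=O)ccc1O`, 570 nM

Compound 3 gives the lowest number of the three; compound 1 sits nearest, within the scatter, and compound 2 furthest, beyond it. Among the compounds with values here, the only measured step at the amine is an 8.6-fold lower number from compound 2 to compound 3 (0.93 log units; beyond the scatter), so changes on this nitrogen can move the number considerably.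

Compound 4 is `CC(C)=CCc1cc(C(=O)Nc2cc3ccc(OCCCN(C)Cc4ccccc4)c(C)c3oc2=O)ccc1O`. It differs from compound 3 as follows: benzyl in place of isopropyl on an amine nitrogen. Within the data shown here, the step from compound 2 to compound 3 shows the amine substituents matter, but no benzyl analogue has been measured, so its direction is open. A step within or just beyond the scatter is expected, a 1.1-fold higher number from compound 3 to compound 4 (0.06 log units; within the scatter). Compound 4 is therefore estimated at 650 nM, with a range of 250 nM to 1700 nM.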

Compound 4, half-maximal inhibitory concentration: 10700 nM
Estimate against measurement, compound 4: 16-fold (1.22 log units) below; measured number above the stated range.
By their numbers in this assay, from the lowest: compounds 3 and 1 (each within the scatter of the next); then compound 2; then compound 4.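

In this assay, this amine nitrogen separates two carbon substituents sharply: benzyl in place of isopropyl gives a 19-fold higher number from compound 3 to compound 4 (1.27 log units; beyond the scatter) and puts the benzyl(methyl)amino compound on the weak side of the diethylamino compound, with a 2.2-fold higher number from compound 2 to compound 4 (0.34 log units; beyond the scatter) as the step. The amine substituent alone therefore spans a wide range on an otherwise unchanged structure. Nothing available accounts for the change at this nitrogen.

Going by these compounds, whether the loss follows from the aromatic ring itself remains open, and a cyclohexylmethyl group on the same nitrogen would test this. A phenethyl group would show how the distance from the nitrogen to the ring bears on the number.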